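A few compounds are considered here, and "the series" means these few. Any claim that something is new, unique, unknown or untested is made for them only; others in the source may bear on it.

Measured compounds:
Compound 1 `NC(=O)c1c(NC(=O)c2ccccc2Cl)sc2c1CCN(Cc1ccccc1Cl)C2` — 27500 nM
Compound 3 `NC(=O)c1c(NC(=O)c2ccccc2F)sc2c1CCN(Cc1ccc(Cl)cc1Cl)C2` — 27500 nM
Compound 2 `NC(=O)c1c(NC(=O)c2ccc(C(F)(F)F)cc2)sc2c1CCN(Cc1c(Cl)cccc1Cl)C2` — > 50000 nM

In a functional assay on HeLa cells (Homo sapiens) for antiproliferative activity, with a stated time of 24 h (on this read-out higher numbers stand for weaker inhibition and lower numbers for stronger inhibition), compound 1 gives 27500 nM. Compound 3 gives 27500 nM in this assay, which is level with compound 1 at the digits shown and within the scatter of it. The value of compound 2 in this assay, > 50000 nM, is a limit of the assay rather than a number; as noted, (the limit of > 50000 nM in this assay, at which 1 of the 3 values shown sits). Among the compounds with values here, no single-point step between measured compounds is available here, so nothing in this set tells how large a change on the amine nitrogen in the ring can move the read-out.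

Compound 4 `NC(=O)c1c(NC(=O)c2ccccc2Cl)sc2c1CCN(C(=S)Nc1ccccc1F)C2` is not yet measured. It differs from compound 1 as follows: a group of 10 heavy atoms (7 carbon, 1 nitrogen, 1 fluorine, 1 sulfur; one six-membered aromatic ring of carbon only) in place of a group of 8 heavy atoms (7 carbon, 1 chlorine; one six-membered aromatic ring of carbon only), on an amine nitrogen in a ring. Within the data shown here, with no measured step to lean on, the most defensible expectation is a step of no more than the scatter, in either direction, from compound 1 to compound 4. Compound 4 is therefore expected to give about 30000 nM in this assay, with a range from 10000 nM to 100000 nM. The step this estimate implies is a 1.1-fold higher number from compound 1 to compound 4 (0.04 log units; within the scatter), and it should be read as an expectation only.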

Compound 4, half-maximal inhibitory concentration: 28700 nM
Compound 4: middle estimate off by 1.0-fold (0.02 log units), on the high side; the range from low to high includes it.
By their numbers in this assay, from the lowest: compounds 1, 3 and 4 (each within the scatter of the next). At a limit, above all of these: compound 2.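

With a 1.0-fold higher number from compound 1 to compound 4 (0.02 log units; within the scatter) in this assay, the amine nitrogen in a ring now has its first measured single-place change. The 2-chlorobenzyl group gives way to a larger group with a double bond outside aromatic rings, a hydrogen-bond donor and a hydrogen-bond acceptor, yet the two compounds stand level within the scatter, so this position tolerates this exchange without a readable change in antiproliferative read-out. Nothing measured here accounts for that level result.

The compounds shown leave open whether a much smaller or charged group on this nitrogen, such as a methyl group, a primary amine or a carboxylic acid, would stay level as well. They also leave open whether this exchange would read the same with other changes elsewhere on the shared core.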